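The compounds below may be only part of what the source reports. "The series", "measured", "known", "first", "only" and "open" are said of these compounds alone.

Of the compounds shown here, three in a shared series have been measured, and they sit close together. In a functional assay on a cell-free system (plasma, Homo sapiens), with a stated time of 3 min (a lower number here means a stronger inhibitor, a higher number a weaker inhibitor), compound 1, `COC(C)(C)[C@@H](O)C(=O)N1[C@H](C(=O)NCc2cc(Cl)ccc2-n2cnnn2)C[C@@H]2C[C@@H]21`, gives 1000 nM. Compound 2, `O=C(NCc1cc(Cl)ccc1-n1cnnn1)[C@@H]1CCON1C(=O)[C@H](O)c1ccccc1`, gives 1500 nM in this assay. Compound 3, `O=C(NCc1cc(Cl)ccc1-n1cnnn1)[C@@H]1[C@@H]2C[C@@H]2CN1C(=O)[C@H](O)Cc1ccccn1`, gives 1700 nM in this assay. Compound 3 carries the highest of the three numbers, but its gap to compound 2 and its gap to compound 1 both fall within the usual scatter of repeated measurements, so the three cannot be ranked against one another on these numbers alone.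

The next compound, compound 4, `CC(C)(C)[C@@H](O)C(=O)N1C[C@H]2C[C@H]2[C@H]1C(=O)NCc1cc(Cl)ccc1-n1cnnn1`, has not yet been measured in this assay. It is derived from compound 3 by one change: tert-butyl in place of (pyridin-2-yl)methyl on a saturated chain carbon bound to a carbonyl carbon and an oxygen on a saturated carbon.

A single change of this kind, in which a group containing a ring is exchanged for a short branched chain at the same place, is expected to move the number only modestly. Since compound 1, which also carries a small branched group at that place, gives 1000 nM, a step from compound 3 to compound 4 of a 1.9-fold lower number from compound 3 to compound 4 (0.28 log units; within the scatter) toward a somewhat stronger inhibitor is expected, though it may well stay within the scatter. The estimate for compound 4 in this assay is 900 nM, with a likely range from 350 nM to 2500 nM.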

Compound 4, half-maximal inhibitory concentration: 1200 nM
Estimate against measurement, compound 4: 1.3-fold (0.12 log units) below; low and high end bracket the measured number.
By their numbers in this assay, from the lowest: compounds 1, 4, 2 and 3 (each within the scatter of the next).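

In this assay the exchange at this saturated chain carbon bound to a carbonyl carbon and an oxygen gives a 1.4-fold lower number from compound 3 to compound 4 (0.15 log units; within the scatter) and so shows no change that can be told apart from repeat-to-repeat noise. For the compounds shown here, this pair is the first direct test of this position: (pyridin-2-yl)methyl, with its six-membered aromatic ring and its hydrogen-bond acceptor, gives way to tert-butyl, which has neither and is smaller by heavy-atom count, yet the read-out stays in the same range. On this shared core, then, neither the ring nor its nitrogen is needed to keep the inhibition seen here, and no measurement shown here explains why this exchange is tolerated.

What the compounds shown leave open is whether this position stays as forgiving with a different kind of group, such as an amine, a carboxylic acid or a longer unbranched alkyl chain, or whether one of these would shift the number beyond the scatter. As far as these compounds go, this is also a single pair on a single core, so it remains unknown whether the same exchange would behave alike on a different core.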